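This account rests on a few compounds, and the source may have more. Where it says the series, first, only, none or still open, it means among the compounds named here.

Measured in an ADME assay on HEK-293T cells (Homo sapiens) for cytotoxicity, read by CCK-8 assay, with a stated time of 48 h; a lower number here means a stronger inhibitor, a higher number a weaker inhibitor:
compound 1 `COc1ccc(Oc2ccc(C(C)C)cc2-c2ccsc2S(=O)(=O)NCCNC(=O)Nc2cc(Cl)cc(Cl)c2)cc1OC` gives 11900 nM.
compound 2 `CC(C)c1ccc(Oc2ccc(O)c(O)c2)c(-c2ccsc2S(=O)(=O)NCCNC(=O)Nc2cc(Cl)cc(Cl)c2)c1` gives > 10000 nM, a limit of the assay and not a number.
compound 3 `COc1ccc(Oc2ccc(C(C)C)cc2-c2ccsc2S(=O)(=O)NCCNC(=S)Nc2cc(C(F)(F)F)cc(C(F)(F)F)c2)cc1OC` gives 10200 nM.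

The gap between compound 3 and compound 1 lies within the usual scatter, so the two cannot be ordered. How the core of compound 1 differs from the core of compound 3 is not broken down here. Compound 2 arises from compound 1 by 3,4-dihydroxyphenyl in place of 3,4-dimethoxyphenyl on an oxygen on an aromatic ring, and the step that the limit leaves unreadable from compound 1 to compound 2 stays unreadable because compound 2 sits at the limit of > 10000 nM in this assay, at which 1 of the 3 values shown sits. Compound 4 `CC(C)c1ccc(Oc2ccc(O)c(O)c2)c(-c2ccsc2S(=O)(=O)NCCNC(=S)Nc2cc(C(F)(F)F)cc(C(F)(F)F)c2)c1` carries the same change from compound 3: 3,4-dihydroxyphenyl in place of 3,4-dimethoxyphenyl on an oxygen on an aromatic ring, at the same place. Since compound 3 already stands close to that limit, compound 4 is expected to end at a limit as well. The step of a 1.5-fold higher number from compound 3 to compound 4 (0.17 log units; within the scatter) is estimated as a slight rise at most. For compound 4 the expected value is 15000 nM. The range for compound 4 is estimated from 7000 nM to 40000 nM.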

Compound 4, half-maximal inhibitory concentration: 18100 nM
The estimate for compound 4 lay 1.2-fold (0.08 log units) below the measured number; the measured number falls inside the stated range.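

In this assay putting 3,4-dihydroxyphenyl in place of 3,4-dimethoxyphenyl gives a 1.8-fold higher number from compound 3 to compound 4 (0.25 log units; within the scatter) and so shows no readable effect of the change on the core of compound 3. On the core of compound 1 the same change cannot be read, as compound 2 gives a limit and not a number: the limit of > 10000 nM in this assay, at which 1 of the 4 values shown sits. Among these compounds, with only one readable step, the series does not show whether the change carries from one core to the other.

The compounds shown leave open whether an amine or a carboxylic acid in place of the two hydroxy groups would read any differently in this assay.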